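The compounds below may be only part of what the source reports. "The series", "measured", "known", "first", "only" and "open" are said of these compounds alone.

Measured in a functional assay on MCF7 cells (Homo sapiens) for antiproliferative activity, with a stated time of 72 h; a lower number here means a stronger inhibitor, a higher number a weaker inhibitor:
- compound 1 `C=C[C@@H]1C[C@@H](Cc2ccc(OC)c(O)c2)[C@H]2C(=O)C=CC(=C)[C@H]21`: 1.17 nM
- compound 2 `C=C1C=CC(=O)[C@@H]2[C@H](Cc3ccc(OCOC)c(F)c3)CC[C@H]12`: 77.2 nM
- compound 3 `C=C1C=CC(=O)[C@@H]2[C@H](Cc3cc(OC)c(OC)c(OC)c3)CC[C@H]12`: > 1000 nM

Among the compounds with values here, compound 1 has the lowest number of the series so far, and compound 2 follows at 77.2 nM, a gap beyond the scatter. Compound 3 gives > 1000 nM, which is a limit and not a number.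

The next compound to be measured is compound 4 `C=C1C=CC(=O)[C@@H]2[C@H](Cc3ccc(OC)c(O)c3)CC[C@H]12`. It differs from compound 1 in a single place: hydrogen in place of vinyl on a saturated ring carbon. The site lies on a five-membered non-aromatic ring of carbon only, part of a fused or bridged system of two rings.

Within the data shown here, no pair of measured compounds isolates this change, so its size has to be judged indirectly. Compound 2 also lacks the vinyl group and gives 77.2 nM, but its aryl substituents are different, so that value offers only loose guidance. In this assay, the expected step of a 10-fold higher number from compound 1 to compound 4 (1.01 log units; beyond the scatter) is towards a higher number, beyond the scatter, with considerable uncertainty. For compound 4 the estimated value is 12 nM, with an expected range of 2 nM to 80 nM.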

Compound 4, half-maximal inhibitory concentration: 3.73 nM
Estimate against measurement, compound 4: 3.2-fold (0.51 log units) above; measured number inside the range.
By their numbers in this assay, from the lowest: compound 1; then compound 4; then compound 2. At a limit, above all of these: compound 3.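

In this assay, within the data shown here, putting hydrogen in place of vinyl on the saturated ring carbon gives a 3.2-fold higher number from compound 1 to compound 4 (0.50 log units; beyond the scatter) and provides the first direct reading of this position, as no earlier pair of compounds isolated the change. The vinyl group is therefore not required for activity in the low nanomolar range on this core, since compound 4 lacks it and still gives 3.73 nM in the same assay, although the loss is beyond the scatter. No available measurement accounts for the size of this step.

Only vinyl and hydrogen can be compared at this ring carbon, so an ethyl chain, a hydroxymethyl group or an amine at the same place would be needed to separate the contribution of the double bond from that of the two carbons it carries. Among these compounds, it also remains open whether the step keeps its size when the aryl substituents differ from the methoxy and hydroxy pattern shared by compound 1 and compound 4, as no second pair carries this change on another aryl group.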